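Swapping the Nitrophenyl Group on the Weakest Compound

The source may report more compounds than this note shows. Statements on the series, on what has been measured and on what is new or still open speak of the compounds shown alone.

- compound 1 `CC1=NN(c2ccccc2)C(=O)[C@]12C(=O)C=CC[C@H]2c1ccccc1[N+](=O)[O-]`: 32400 nM
- compound 2 `CC1=NN(c2ccccc2)C(=O)[C@@]12C(=O)C=CC[C@@H]2c1ccccc1[N+](=O)[O-]`: 68300 nM
- compound 3 `CC1=NN(c2ccccc2)C(=O)[C@]12C(=O)C=CC[C@H]2c1ccc(C)cc1`: 5720 nM

In a functional assay on MDA-MB-231 cells (Homo sapiens) for inhibition, read by MTT assay, with a stated time of 72 h (a higher number here means a weaker inhibitor, a lower number a stronger inhibitor), compound 2 gives 68300 nM, the highest of the three numbers, which makes it the weakest inhibitor measured so far. Its mirror image does somewhat better: a modest step, a 2.1-fold higher number from compound 1 to compound 2 (0.32 log units; beyond the scatter), arises from the fact that compounds 1 and 2 differ only in the configuration as drawn.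

The next compound to be tested is compound 4 `CC1=NN(c2ccccc2)C(=O)[C@@]12C(=O)C=CC[C@@H]2c1cccc(C)c1`. It keeps the configuration of compound 2 but exchanges one group: 3-methylphenyl in place of 2-nitrophenyl on a saturated ring carbon. The closest measured swap is a 5.7-fold lower number from compound 1 to compound 3 (0.75 log units; beyond the scatter), with 4-methylphenyl in place of 2-nitrophenyl on the same saturated ring carbon, though in the mirror-image configuration and with 4-methylphenyl rather than 3-methylphenyl. A step of similar size is therefore expected in this assay, towards a lower number and so a stronger inhibitor. The expected change is a 5.7-fold lower number from compound 2 to compound 4 (0.76 log units; beyond the scatter). For compound 4 the estimated value is 12000 nM, with an expected range from 4500 nM to 32000 nM.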

Compound 4, half-maximal inhibitory concentration: 6800 nM
For compound 4 the middle estimate is 1.8-fold (0.25 log units) above the measured one; measured number inside the range.
By their numbers in this assay, from the lowest: compounds 3 and 4 (each within the scatter of the next); then compound 1; then compound 2.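

In this assay, putting 3-methylphenyl in place of 2-nitrophenyl on the saturated ring carbon gives a modest step towards a stronger inhibitor, a 10-fold lower number from compound 2 to compound 4 (1.00 log units; beyond the scatter). Among the compounds shown here, until now, leaving 2-nitrophenyl had been seen only in the configuration of compound 1, with 4-methylphenyl entering; this result shows a lower number in the mirror-image configuration too, and with 3-methylphenyl as the entering group. Nothing measured here explains why the number falls.

This single swap removes a nitro group and adds a methyl group at once, so the compounds shown cannot tell which of the two changes matters. A plain phenyl, or a phenyl carrying a methoxy group or an amine, on the same carbon would help to separate them.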